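Aryl variation on the butenolide series: compound 3

A few compounds are considered here, and "the series" means these few. Any claim that something is new, unique, unknown or untested is made for them only; others in the source may bear on it.

Compound 1 `CC(C)=CCC/C(C)=C/CCC1=C[C@H](c2ccc(C)cc2)OC1=O` is the stronger of the two measured compounds in an assay on microsomes from liver for inhibition of 3-hydroxy-3-methylglutaryl-coenzyme A reductase (Sus scrofa), read by colorimetric assay (a lower number here means a stronger inhibitor, a higher number a weaker inhibitor), the assay that gives compound 1 a value of 18100 nM. Compound 2 `CC(C)=CCC/C(C)=C/CCC1=C[C@H](c2ccc(C(C)C)cc2)OC1=O` gives 112000 nM in this assay, and the step of a 6.2-fold higher number from compound 1 to compound 2 (0.79 log units; beyond the scatter) shows that enlarging the group on the aromatic carbon weakens inhibition by a modest margin. Compound 3 `CC(C)=CCC/C(C)=C/CCC1=C[C@H](c2cc(F)ccc2F)OC1=O` is not yet measured; it differs from compound 1 by 2,5-difluorophenyl in place of 4-methylphenyl on a saturated ring carbon. Among the measured compounds shown here, no measured step covers this exchange: the only known step swaps one alkyl group for a larger one on the same aromatic carbon, whereas here the methyl leaves and two fluorines enter at other places on the ring. The measured step therefore gives no direct direction, and the expectation is a step of about a 1.2-fold higher number from compound 1 to compound 3 (0.08 log units; within the scatter) in this assay, near the scatter. Compound 3 is thus estimated at 22000 nM in this assay, within 6000 nM to 80000 nM.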

Compound 3, half-maximal inhibitory concentration: 25100 nM
Beside the measured number, compound 3's estimate is 1.1-fold (0.06 log units) below it, within the range that was stated.
By their numbers in this assay, from the lowest: compounds 1 and 3 (each within the scatter of the next); then compound 2.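

In this assay, the exchange of 4-methylphenyl for 2,5-difluorophenyl gives a 1.4-fold higher number from compound 1 to compound 3 (0.14 log units; within the scatter), so compound 1 and compound 3 cannot be told apart here. This shows that the aryl group on this saturated ring carbon can lose its methyl and carry two fluorines without a step beyond the scatter, whereas the isopropyl exchange gives a 6.2-fold higher number from compound 1 to compound 2 (0.79 log units; beyond the scatter). Nothing available explains this result.

Going by these compounds, the fluorines and the loss of the methyl come as one exchange, so the share of each remains open, as does the reading for a single fluorine or an unsubstituted phenyl. Also open, on these data alone, is whether an amine or a carboxylic acid on the aromatic ring would give a step beyond the scatter in this assay, and in which direction.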